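Nitro for cyano on two cores of the series

A few compounds are considered here, and "the series" means these few. Any claim that something is new, unique, unknown or untested is made for them only; others in the source may bear on it.

Measured so far:
compound 1 `CC(O)(COc1cc(C(F)(F)F)cc(C(F)(F)F)c1)C(=O)Nc1ccc(C#N)cc1C(F)(F)F`: 4070 nM
compound 2 `CC(O)(COc1cc(C(F)(F)F)cc(C(F)(F)F)c1)C(=O)Nc1ccc([N+](=O)[O-])cc1C(F)(F)F`: 16100 nM
compound 3 `CC(O)(CS(=O)(=O)c1cc(C(F)(F)F)cc(C(F)(F)F)c1)C(=O)Nc1ccc(C#N)cc1C(F)(F)F`: "nd(insoluble)" (no result reported)

In a functional assay on CWR22R cells (Homo sapiens) for antiproliferative activity, read by fluorescence and propidium iodide staining, with a stated time of 96 h (on this read-out higher numbers stand for weaker inhibition and lower numbers for stronger inhibition), compound 1 gives 4070 nM and compound 2 gives 16100 nM; the change nitro in place of cyano on an aromatic carbon made a 4.0-fold higher number from compound 1 to compound 2 (0.60 log units; beyond the scatter). Compound 3 was insoluble and gave "nd(insoluble)" (no result reported) in this assay; how its core differs from the core of compound 1 is not broken down here. Compound 4 `CC(O)(CS(=O)(=O)c1cc(C(F)(F)F)cc(C(F)(F)F)c1)C(=O)Nc1ccc([N+](=O)[O-])cc1C(F)(F)F` differs from compound 3 by nitro in place of cyano on an aromatic carbon, the same change that separates compound 1 from compound 2. No number exists for compound 3. Among the compounds with values here, the step to compound 4 cannot be sized beside the earlier one; the only anchor is that compound 1 and compound 2 both sit high in this assay. Compound 4 is expected near 20000 nM, estimated between 5000 nM and 80000 nM, and may well return no number at all.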

Compound 4, half-maximal inhibitory concentration: 2410 nM
Compound 4: the middle estimate sits 8.3-fold (0.92 log units) above what was measured; the measured number lies below the stated range.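

Within the data shown here, compound 3 stands at "nd(insoluble)" (no result reported) and compound 4 at 2410 nM in this series, so no step between them can be read. No measured property bears on this result.
Left open is whether a 4.0-fold higher number from compound 1 to compound 2 (0.60 log units; beyond the scatter) has any counterpart on the core of compound 3.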